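Working notes: adding fluoro to compound 2

This account rests on a few compounds, and the source may have more. Where it says the series, first, only, none or still open, it means among the compounds named here.

Measured so far in a functional assay (Nicotiana tabacum); on this read-out lower numbers stand for stronger inhibition and higher numbers for weaker inhibition:
- compound 1 `CCCCCNc1nc(SC)nc2ncccc12` gives 650 nM
- compound 2 `CSc1nc(Nc2ccccc2)c2cccnc2n1` gives 15900 nM

Of these two numbers, compound 2 holds the higher, at 15900 nM, so it is the weaker inhibitor in this assay. Within the data shown here, the only measured step is a 24-fold higher number from compound 1 to compound 2 (1.39 log units; beyond the scatter), which is large and beyond the scatter. It comes from phenyl in place of pentyl on a nitrogen on an aromatic ring.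

The next compound is compound 3 `CSc1nc(Nc2ccc(F)cc2)c2cccnc2n1`, which keeps the phenyl of compound 2 and carries one change: fluoro in place of hydrogen on an aromatic carbon. Among the measured compounds shown here, the measured step bears on this only loosely, since it replaced the whole group on the nitrogen, and no measured pair shows fluoro in place of hydrogen on an aromatic carbon. Its size therefore does not transfer. No step beyond the scatter is expected in this assay, and the data fix no direction.

The expected change is a 1.1-fold lower number from compound 2 to compound 3 (0.06 log units; within the scatter). For compound 3 the estimated value is 14000 nM, with an expected range of 5000 nM to 40000 nM.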

Compound 3, half-maximal inhibitory concentration: 2620 nM
Compound 3: middle estimate off by 5.3-fold (0.73 log units), on the high side; measured number below the stated range.
By their numbers in this assay, from the lowest: compound 1; then compound 3; then compound 2.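

In this assay, the aromatic carbon para to a large group proves responsive to a very small change: a 6.1-fold lower number from compound 2 to compound 3 (0.78 log units; beyond the scatter), so one fluoro in place of hydrogen moves the number beyond the scatter, towards stronger inhibition. The earlier step, which replaced the whole group on the nitrogen, could not show that the phenyl itself responds to a single-atom change. Even so, compound 3 at 2620 nM still has a higher number than compound 1 at 650 nM, so fluoro closes only part of the gap opened when a 24-fold higher number from compound 1 to compound 2 (1.39 log units; beyond the scatter).

Nothing at hand gives a reason for this shift.

With one substituent at one place, the compounds shown leave open whether the gain belongs to fluoro specifically or would also appear with chloro, methyl or methoxy at the same carbon. They also leave open whether fluoro on another carbon of the phenyl would do the same, and whether a fluoro-bearing benzyl group on the nitrogen would bring the number closer to that of compound 1.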